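The source may hold more compounds than are shown below. What is called first, only, known or untested is meant among the compounds shown, and "the series" means these compounds.

Compound 1 `CCCC1CCC(OC(=O)N[C@@H](CC(C)C)C(=O)N[C@H](C=O)C[C@@H]2CCNC2=O)CC1` carries a formyl group on its core, and in a toxicity assay on L929 cells (Mus musculus) for cytotoxicity (a lower number here means that less compound is tolerated, a higher number that more compound is tolerated), compound 1 reaches only the limit of the assay, > 100000 nM, not a number. Compound 2 `CC(C)C[C@H](NC(=O)OC1CCC(F)(F)CC1)C(=O)N[C@H](C=O)C[C@@H]1CCNC1=O` differs from compound 1 as told by 4,4-difluorocyclohexyl in place of 4-propylcyclohexyl on an oxygen next to a carbonyl group. In this assay compound 2 also stops at the limit, > 100000 nM. The step that the two limits leave unreadable from compound 1 to compound 2 is therefore not readable, since both values sit at the limit. Compound 3 `CCCC1CCC(OC(=O)N[C@@H](CC(C)C)C(=O)N[C@@H](C[C@@H]2CCNC2=O)C(O)S(=O)(=O)O)CC1` differs from compound 1 as told by hydroxy(sulfo)methyl in place of formyl on a saturated chain carbon bound to an amide-type nitrogen and a saturated chain carbon; in this assay compound 3 again gives the limit > 100000 nM, so a step that the two limits leave unreadable from compound 1 to compound 3 is not readable either, a position summed up by the limit of > 100000 nM in this assay, at which 3 of the 3 values shown sit. Compound 4 `CC(C)C[C@H](NC(=O)OC1CCC(F)(F)CC1)C(=O)N[C@@H](C[C@@H]1CCNC1=O)C(O)S(=O)(=O)O` is not yet measured; it differs from compound 3 as told by 4,4-difluorocyclohexyl in place of 4-propylcyclohexyl on an oxygen next to a carbonyl group, the same kind of change as from compound 1 to compound 2. Its place lines match word for word. From the step that the two limits leave unreadable from compound 1 to compound 2 nothing larger than a step within the limit is expected for compound 4, so a step that the limit leaves unreadable from compound 3 to compound 4 is the expected step. The expected value of compound 4 in this assay is 200000 nM, most likely again only a limit.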

Compound 4, half-maximal cytotoxic concentration: > 100000 nM
Compound 4: only a limit was reported; the forecaster's own chance of this, stated with the estimate: 90%; the middle value is on the limit's open side.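

Compound 4 gives only a limit in this assay, so its steps from compound 2 and from compound 3 cannot be read: the limit of > 100000 nM in this assay, at which 4 of the 4 values shown sit.

The compounds shown leave open at what concentration any of them harms these cells, and whether either change affects that concentration.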